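A few compounds are considered here, and "the series" means these few. Any claim that something is new, unique, unknown or untested is made for them only; others in the source may bear on it.

Compound 1, `CS(=O)(=O)c1ccc(-c2[nH]c(Br)c(Cl)c2-c2ccc(F)cc2)cc1`, in a functional assay on the whole organism with Rattus norvegicus as the target; on this read-out higher numbers stand for an effect only at larger amounts of compound and lower numbers for an effect already at smaller amounts: 9.98 uM
Compound 2, `CS(=O)(=O)c1ccc(-c2[nH]c(Cl)c(Cl)c2-c2ccc(F)cc2)cc1`: 3.9 uM
Compound 3, `CS(=O)(=O)c1ccc(-c2[nH]c(C(=O)C(F)(F)F)cc2-c2ccc(F)cc2)cc1`: 47.2 uM

Compound 3 stands at the highest of the three numbers; compound 2 has the lowest, and compound 1 lies between the two. Compound 4, `CS(=O)(=O)c1ccc(-c2[nH]ccc2-c2ccc(F)cc2)cc1`, differs from compound 3 by hydrogen in place of (trifluoromethyl)carbonyl on an aromatic carbon. Among the measured compounds shown here, only one measured step touches the same ring carbon: a 2.6-fold lower number from compound 1 to compound 2 (0.41 log units; beyond the scatter), a modest exchange of one halogen for another. For the measured compounds named here, no measured step removes a group from that carbon altogether, so the weight of the present change is uncertain. Since both halogen-bearing compounds 1 and 2 give lower numbers than compound 3, a moderate decrease is expected, estimated as a 3.1-fold lower number from compound 3 to compound 4 (0.50 log units; beyond the scatter). Compound 4 is therefore estimated at 15 uM, with a range from 4 uM to 60 uM.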

Compound 4, concentration for half-maximal effect: > 317 uM
Compound 4: only a limit was reported; the forecaster's own chance of this, stated with the estimate: 10%; middle value at least 21-fold (1.32 log units) away from the limit.
By their numbers in this assay, from the lowest: compound 2; then compound 1; then compound 3. At a limit, above all of these: compound 4.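

Earlier, this carbon had only shown one halogen exchanged for another; here, emptying it altogether gives an at least 6.7-fold higher number from compound 3 to compound 4 (0.82 log units; beyond the scatter). Compound 4 reaches only a limit in this assay: the limit of > 317 uM in this assay, at which 1 of the 4 values shown sits. The change is therefore larger than the halogen exchange, and with hydrogen on this carbon, next to the ring nitrogen, no number was obtained within that limit.

As far as these compounds go, how a methyl, a nitrile or an acetyl on this carbon would read remains open. So does whether the carbonyl or the trifluoromethyl carries the difference between compound 3 and compound 4.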